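This account rests on a few compounds, and the source may have more. Where it says the series, first, only, none or still open, it means among the compounds named here.

Measured so far:
compound 1 `Cn1cc(-c2nc3c(-c4ccc(CNC(=O)c5nc(C6(C)CC6)no5)c(F)c4)ccnc3[nH]2)cn1` gives 2.8 10^-6 cm/s in an ADME assay on Caco-2 cells (Homo sapiens) for permeability, in the apical to basolateral direction; a higher number here means that the compound crosses the layer faster, a lower number that the compound crosses the layer more slowly
compound 2 `Cn1cc(-c2nc3c(-c4ccc(CNC(=O)c5noc(C(C)(C)C)n5)c(F)c4)ccnc3[nH]2)cn1` gives 2.5 10^-6 cm/s
compound 3 `CC1CC2(C1)CN(C(=O)NCc1ccc(-c3ccnc4[nH]c(-c5cnn(C)c5)nc34)cc1F)C2` gives 8 10^-6 cm/s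

Compound 3 stands highest of the three numbers in this assay: the step of a 2.9-fold higher number from compound 1 to compound 3 (0.46 log units; beyond the scatter) and the step of a 3.2-fold higher number from compound 2 to compound 3 (0.51 log units; beyond the scatter) are both beyond the scatter, whereas a 1.1-fold lower number from compound 1 to compound 2 (0.05 log units; within the scatter) is within it. Compound 4 `Cn1cc(-c2nc3c(-c4ccc(CNC(=O)N5CC(OC(C)(C)C)C5)c(F)c4)ccnc3[nH]2)cn1` keeps the core of compound 3 and changes the group on the carbonyl carbon: a group of 9 heavy atoms (7 carbon, 1 nitrogen, 1 oxygen; one four-membered non-aromatic ring with 1 hetero atom) in place of a group of 8 heavy atoms (7 carbon, 1 nitrogen; one four-membered non-aromatic ring of carbon only, one four-membered non-aromatic ring with 1 hetero atom), on a carbonyl carbon. Among the measured compounds shown here, no measured step exchanges two groups of this kind on that carbonyl carbon, so the measured steps give no direct guide; they show only that both compounds bearing a four-membered ring with one hetero atom on the carbonyl carbon sit at the high end. A step within the scatter is expected: a 1.3-fold lower number from compound 3 to compound 4 (0.12 log units; within the scatter). Compound 4 is estimated at 6 10^-6 cm/s, in the range 3 10^-6 cm/s to 12 10^-6 cm/s.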

Compound 4, apparent permeability: 0.4 10^-6 cm/s
Compound 4: middle estimate off by 15-fold (1.18 log units), on the high side, outside the stated range (below it).
By their numbers in this assay, from the lowest: compound 4; then compounds 2 and 1 (each within the scatter of the next); then compound 3.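

On the carbonyl carbon, a four-membered ring with one hetero atom does not by itself keep the number high in this assay, since compounds carrying such a ring can differ widely (a 20-fold lower number from compound 3 to compound 4 (1.30 log units; beyond the scatter)). The group of compound 4 also reads lower than both groups with a five-membered aromatic ring (a 6.3-fold lower number from compound 2 to compound 4 (0.80 log units; beyond the scatter) and a 7.0-fold lower number from compound 1 to compound 4 (0.85 log units; beyond the scatter)). No measurement at hand explains these drops. The compounds shown leave open whether the oxygen or the rest of the entering group goes with the fall, and how a methoxy or hydroxyl group would read in its place.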